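Methoxy Added to the Phenylethenyl Amide

The compounds below may be only part of what the source reports. "The series", "measured", "known", "first", "only" and "open" are said of these compounds alone.

compound 1, `CN1[C@@H]2c3[nH]c4ccccc4c3C[C@H]1[C@H](C#N)N1[C@@H](CNC(=O)c3cccc(C(F)(F)F)c3)c3[nH]c4ccccc4c3C[C@@H]21`: 110 nM
compound 2, `CN1[C@@H]2c3[nH]c4ccccc4c3C[C@H]1[C@H](C#N)N1[C@@H](CNC(=O)/C=C/c3ccccc3)c3[nH]c4ccccc4c3C[C@@H]21`: 7190 nM

Of the two compounds measured in a functional assay on MCF7 cells (Homo sapiens) for cytotoxicity, read by MTT assay, with a stated time of 72 h (a lower number here means a stronger inhibitor, a higher number a weaker inhibitor), compound 2 stands highest, its value being 7190 nM, while compound 1 gives 110 nM. Compound 3 `COc1ccc(/C=C/C(=O)NC[C@H]2c3[nH]c4ccccc4c3C[C@H]3[C@H]4c5[nH]c6ccccc6c5C[C@@H]([C@H](C#N)N23)N4C)cc1` differs from compound 2 by methoxy in place of hydrogen on an aromatic carbon. Among the compounds with values here, the one measured step, a 65-fold higher number from compound 1 to compound 2 (1.82 log units; beyond the scatter), exchanged the whole aryl group on the carbonyl; no measured step adds a substituent to the phenyl ring of the phenylethenyl group, so there is no direct guide. A small step, within the scatter, is expected: a 1.2-fold lower number from compound 2 to compound 3 (0.08 log units; within the scatter). Compound 3 is estimated at 6000 nM, from 2000 nM to 20000 nM.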

Compound 3, half-maximal inhibitory concentration: 4220 nM
For compound 3 the middle estimate is 1.4-fold (0.15 log units) above the measured one; low and high end bracket the measured number.
By their numbers in this assay, from the lowest: compound 1; then compounds 3 and 2 (each within the scatter of the next).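

In this assay, methoxy on the aromatic ring of the phenylethenyl amide brings a 1.7-fold lower number from compound 2 to compound 3 (0.23 log units; within the scatter), so this change cannot be told apart from no change at all. The large gap to the 3-(trifluoromethyl)phenyl amide remains, with a 38-fold higher number from compound 1 to compound 3 (1.58 log units; beyond the scatter), so methoxy at this place does not close it. Nothing available explains either step.

On these data alone, whether an amine or a carboxylic acid at the same ring place would shift the number stays open. So does the effect of a longer chain between the carbonyl and the ring.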